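Chain Extension on a Phenyl-Bearing Cyclic Guanidine Scaffold

This account rests on a few compounds, and the source may have more. Where it says the series, first, only, none or still open, it means among the compounds named here.

Compound 1 `CCC1C(=O)N(CCCCCOc2ccc(Cl)cc2)/C(=N\C#N)N1c1ccncc1` and compound 2 `CCC1C(=O)N(CCCCCCOc2ccc(Cl)cc2)/C(=N\C#N)N1c1ccncc1` share a core and differ only in the length of the chain that carries the 4-chlorophenoxy group. In a functional assay on HONE1 cells for cytotoxicity against HONE1 cell line (Homo sapiens) (a higher number here means a weaker inhibitor, a lower number a stronger inhibitor), compound 1 gives 4830 nM and compound 2 gives 3870 nM; the change (4-chlorophenoxy)methyl in place of 4-chlorophenoxy on a saturated chain carbon, five bonds along the chain from an amide-type nitrogen in a ring produced a 1.2-fold lower number from compound 1 to compound 2 (0.10 log units; within the scatter). Compound 3 `N#C/N=C1\N(CCCCCCOc2ccc(Cl)cc2)C(=O)C(c2ccccc2)N1c1ccncc1` gives 337 nM in this assay, which is an 11-fold lower number from compound 2 to compound 3 (1.06 log units; beyond the scatter), making compound 3 the lowest of the three numbers.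

Compound 4 `N#C/N=C1\N(CCCCCCCOc2ccc(Cl)cc2)C(=O)C(c2ccccc2)N1c1ccncc1` is related to compound 3 by (4-chlorophenoxy)methyl in place of 4-chlorophenoxy on a saturated chain carbon, six bonds along the chain from an amide-type nitrogen in a ring, the same kind of change as from compound 1 to compound 2, though the place differs: five bonds along the chain in the earlier pair, six bonds here. The difference between the core of compound 1 and the core of compound 3 is not broken down here.

The lengthening is expected to leave the number roughly unchanged, an estimated 1.1-fold lower number from compound 3 to compound 4 (0.05 log units; within the scatter), because a 1.2-fold lower number from compound 1 to compound 2 (0.10 log units; within the scatter) stayed within the scatter. Compound 4 is thus expected to give about 300 nM in this assay, estimated between 140 nM and 700 nM.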

Compound 4, half-maximal inhibitory concentration: 398 nM
Beside the measured number, compound 4's estimate is 1.3-fold (0.12 log units) below it; low and high end bracket the measured number.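

In this assay, the added chain carbon gave a 1.2-fold higher number from compound 3 to compound 4 (0.07 log units; within the scatter) and so left the number effectively unchanged. Set beside the earlier step, the same change carries from one core to the other with no difference that these data can separate: the same change on two cores in this assay, a 1.2-fold lower number (0.10 log units; within the scatter) from compound 1 to compound 2 and a 1.2-fold higher number (0.07 log units; within the scatter) from compound 3 to compound 4, 1.5-fold (0.17 log units) apart, within the scatter of two such steps. Both steps are small, so their agreement shows only that this one added carbon changes little on these two cores at these chain lengths; two pairs, which also differ in how far along the chain the change sits, cannot show that the same holds on other cores or at other chain lengths.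

The compounds shown leave open how a shorter chain, or a chain longer than that of compound 4, would behave on the core of compound 3. Also open, as far as these compounds go, is whether an amine or a carboxylic acid in place of the chlorine on the 4-chlorophenoxy group would keep the number of compound 3 or compound 4.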